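Nitro in Place of Hydrogen on the Benzyl Ring

A few compounds are considered here, and "the series" means these few. Any claim that something is new, unique, unknown or untested is made for them only; others in the source may bear on it.

Compound 1 `OCc1cn(Cc2ccccc2)c2ccccc12`: 30 nM
Compound 2 `OCc1cn(Cc2ccc(Br)cc2)c2ccccc12`: 390 nM

Within the data shown here, in a functional assay on T29Kt1 cells (Homo sapiens) for cytotoxicity, read by sulforhodamine B assay, with a stated time of 3 days (a lower number here means a stronger inhibitor, a higher number a weaker inhibitor), compound 1 gives the lowest of the two numbers measured so far, and the step of a 13-fold higher number from compound 1 to compound 2 (1.11 log units; beyond the scatter) is large and beyond the scatter. Compound 3 `O=[N+]([O-])c1cccc(Cn2cc(CO)c3ccccc32)c1` differs from compound 1 in one place: nitro in place of hydrogen on an aromatic carbon. Among the measured compounds shown here, the only measured step that bears on this change is the one to compound 2, where a different group entered and weakened inhibition strongly. A weaker compound than compound 1 is therefore expected, though the step of a 5.0-fold higher number from compound 1 to compound 3 (0.70 log units; beyond the scatter) is estimated to be smaller. For compound 3 the expected value is 150 nM, within a range of 40 nM to 600 nM.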

Compound 3, half-maximal inhibitory concentration: 390 nM
Estimate against measurement, compound 3: 2.6-fold (0.41 log units) below, within the range that was stated.
By their numbers in this assay, from the lowest: compound 1; then compounds 2 and 3 (each within the scatter of the next).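

In this assay, nitro on an aromatic carbon of the six-membered aromatic ring, meta to a large group, gives a 13-fold higher number from compound 1 to compound 3 (1.11 log units; beyond the scatter). The loss of strength seen with bromo is therefore not confined to that one group: with both bromo and nitro on this ring, compound 1, which has only hydrogen there, remains the stronger inhibitor. No measured evidence here explains this loss. On these data alone, whether an amine or a methoxy group on this ring would keep the low number of compound 1 remains open.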